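The source may hold more compounds than are shown below. What is called first, only, known or untested is meant among the compounds shown, and "the series" means these compounds.

Three compounds share one core. Compound 1 `COc1cc(NC(=O)Nc2cc(Nc3ccc(C(C)(C)C)cc3)ncn2)cc(OC)c1` gives 32.7% in a functional assay on HCC827 cells (Homo sapiens) for inhibition, read by MTT assay, with a stated time of 48 h, tested at 10 uM; a higher number here means more inhibition at the concentration tested (going by the name of the read-out), a lower number less inhibition. Compound 2 `Cc1ccc(Nc2cc(NC(=O)Nc3c(Cl)cccc3Cl)ncn2)cc1F` gives 85.3% in this assay, and compound 3 `CCc1ccc(Nc2cc(NC(=O)Nc3cc(OC)cc(OC)c3)ncn2)cc1` gives 66.2%. On these numbers compound 3 stands second of the three: compound 2 lies above it beyond the scatter, and compound 1 lies below it beyond the scatter.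

Compound 4 `COc1cc(NC(=O)Nc2cc(Nc3ccc(C)c(C)c3)ncn2)cc(OC)c1` has not yet been measured in this assay. It differs from compound 3 in one place: 3,4-dimethylphenyl in place of 4-ethylphenyl on a nitrogen on an aromatic ring.

For the measured compounds named here, the only measured step that touches the same part of the molecule is a number 33.5 percentage points higher from compound 1 to compound 3 (beyond the scatter), a large rise. Going by the values given here, the present change is of a different kind, since the two structures have the same atoms joined differently, and no measured pair shows this exact exchange, so a step of that size is not expected. The expected step of a number 6.2 percentage points lower from compound 3 to compound 4 (within the scatter) is small and lies within the scatter. Compound 4 is estimated at 60%, between 40% and 80%.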

Compound 4, a percentage reported as inhibition, at one concentration (the size of the read-out at that concentration, not a potency): 45.7%
Compound 4: the middle estimate sits 14.3 percentage points above what was measured, and the stated range covers the measured number.
By their numbers in this assay, from the lowest: compound 1; then compound 4; then compound 3; then compound 2.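

In this assay, the group on the nitrogen proves sensitive to the arrangement of its atoms as well as their number: 3,4-dimethylphenyl in place of 4-ethylphenyl, the same atoms joined differently, gives a number 20.5 percentage points lower from compound 3 to compound 4 (beyond the scatter). Against 4-(tert-butyl)phenyl, the same 3,4-dimethylphenyl group gives a number 13 percentage points higher from compound 1 to compound 4 (beyond the scatter), so the three groups at this place rank 4-(tert-butyl)phenyl lowest, 3,4-dimethylphenyl in the middle and 4-ethylphenyl highest, each step beyond the scatter. No measurement at hand explains this order.

As far as these compounds go, it remains open how a longer chain such as 4-propylphenyl or a group carrying an amine, such as 4-(dimethylamino)phenyl, would read at this place. Compound 2 differs from these compounds in more than one place, so its number cannot be assigned to either change.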